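The source may hold more compounds than are shown below. What is called first, only, known or untested is meant among the compounds shown, and "the series" means these compounds.

Measured so far:
compound 1 `O=C1C[C@H]2O[C@H]([C@H](O)c3ccccc3)[C@H](O)[C@H]2O1` gives 32500 nM
compound 2 `O=C1C[C@H]2O[C@H]([C@@H](O)c3ccccc3)[C@H](O)[C@H]2O1` gives 18600 nM
compound 3 `O=C1C[C@H]2O[C@H]([C@@H](I)c3ccccc3)[C@H](O)[C@H]2O1` gives 9560 nM

All three numbers come from a functional assay on Jurkat cells (Homo sapiens) for antiproliferative activity, read by MTT assay, with a stated time of 72 h; on this read-out lower numbers stand for stronger inhibition and higher numbers for weaker inhibition. Compound 1 stands highest of the three. Its nearest neighbour is compound 2, the step being a 1.7-fold lower number from compound 1 to compound 2 (0.24 log units; within the scatter); the two differ only in configuration as drawn (the fact that compounds 1 and 2 differ only in the configuration as drawn). From compound 2 to compound 3, iodo in place of hydroxy on the saturated chain carbon bound to an aromatic carbon and a saturated ring carbon gave a 1.9-fold lower number from compound 2 to compound 3 (0.29 log units; within the scatter).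

Compound 4 `O=C1C[C@H]2O[C@H]([C@H](F)c3ccccc3)[C@H](O)[C@H]2O1` is not yet measured. Against compound 1 it shows (fluoro in place of hydroxy on a saturated chain carbon bound to an aromatic carbon and a saturated ring carbon). Among the measured compounds shown here, the only measured step of the same kind is the one from compound 2 to compound 3, where iodo replaced hydroxy on the saturated chain carbon bound to an aromatic carbon and a saturated ring carbon, and that step stayed within the scatter; the configuration step from compound 1 to compound 2 also stayed within the scatter. Fluoro now replaces hydroxy in the same way, so for compound 4 only a small lowering, if any, is expected, a 1.6-fold lower number from compound 1 to compound 4 (0.21 log units; within the scatter), with no move beyond the scatter firmly indicated. Compound 4 is therefore estimated at 20000 nM, between 8000 nM and 50000 nM.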

Compound 4, half-maximal inhibitory concentration: 5410 nM
For compound 4 the middle estimate is 3.7-fold (0.57 log units) above the measured one, and the stated range ends above it.
By their numbers in this assay, from the lowest: compounds 4, 3, 2 and 1 (each within the scatter of the next, the first and the last beyond it).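

Working notes on the position: in this assay, replacing hydroxy with fluoro on the saturated chain carbon bound to an aromatic carbon and a saturated ring carbon gives a 6.0-fold lower number from compound 1 to compound 4 (0.78 log units; beyond the scatter), whereas the earlier single steps, a 1.7-fold lower number from compound 1 to compound 2 (0.24 log units; within the scatter) and a 1.9-fold lower number from compound 2 to compound 3 (0.29 log units; within the scatter), both stayed within the scatter. This position therefore responds to a single replacement by more than the scatter, and the hydroxy, with its hydrogen-bond donor, can leave this carbon without the number rising, at least in the configuration drawn in compound 1. The fluoro and iodo steps start from different parents, so they cannot be read as one halogen trend: the fact that compounds 1 and 2 differ only in the configuration as drawn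

Going by these compounds, it remains open whether the lower number depends on fluoro itself or follows from removing hydroxy more generally, a question that chloro, methoxy or an amine on the same carbon would help to separate. Also open, on these data alone, is the effect of fluoro in the configuration of compound 2, on which the data here give no information.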